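The compounds below may be only part of what the source reports. "The series", "measured", "known", "first", "only" and "open" are said of these compounds alone.

For the measured compounds named here, compound 2 `COC(=O)/C=C/c1cccc(N(Cc2ccc(/C=C/C(=O)NC(C)(C)C)cc2)C(=O)C2CCCCC2)c1` is one of only two compounds that have been tested in an assay on isolated protein with Bile acid receptor (Homo sapiens) as the target; on this read-out lower numbers stand for an effect already at smaller amounts and higher numbers for an effect only at larger amounts of compound. In this assay compound 2 gives merely a limit of the assay, > 1000 nM. Its partner, compound 1 `COC(=O)/C=C/c1cccc(N(Cc2ccc(/C=C/C(=O)N(C)C)cc2)C(=O)C2CCCCC2)c1`, likewise gives only a limit in this assay, namely > 1000 nM. Going by the values given here, the single measured step, a step that the two limits leave unreadable from compound 1 to compound 2, therefore cannot be read, and the only common ground is that (the limit of > 1000 nM in this assay, at which 2 of the 2 values shown sit). Compound 3 `COC/C=C/c1ccc(CN(C(=O)C2CCCCC2)c2cccc(/C=C/C(=O)OC)c2)cc1` has not yet been measured in this assay. It differs from compound 2 in that (methoxymethyl in place of (tert-butyl)carbamoyl on a double-bonded chain carbon bound to a double-bonded chain carbon). Among the compounds with values here, no measured step bears on this change: the one step that exists sits between two limits and carries no size, so nothing in the data shows whether trading the carbamoyl for an ether moves the read-out in either direction. The expectation rests on where compound 2 stands. The expected step is a step that the limit leaves unreadable from compound 2 to compound 3, without a reliable direction. Compound 3 is expected to give about 2500 nM in this assay, within a range from 600 nM to 15000 nM, and most probably again only a limit.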

Compound 3, half-maximal effective concentration: 233 nM
Estimate against measurement, compound 3: 11-fold (1.03 log units) above; the measured number lies below the stated range.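

In this assay, the place on a double-bonded chain carbon bound to a double-bonded chain carbon now proves sensitive to what sits there, which the two carbamoyl compounds alone could not show. Methoxymethyl in place of (tert-butyl)carbamoyl gives an at least 4.2-fold lower number from compound 2 to compound 3 (0.63 log units; beyond the scatter), and methoxymethyl in place of dimethylcarbamoyl gives an at least 4.2-fold lower number from compound 1 to compound 3 (0.63 log units; beyond the scatter), so compound 3 is the only compound shown with a measured number rather than a limit. The true size of both steps stays unknown and the step between the two carbamoyl compounds cannot be read, since those two compounds remain at a limit: the limit of > 1000 nM in this assay, at which 2 of the 3 values shown sit.

The compounds shown do not tell whether the oxygen of the methoxymethyl group matters or whether removing the carbamoyl is enough, since no plain propenyl chain, hydroxymethyl or ethoxymethyl group appears at this place. As far as these compounds go, how a carboxylic acid, an amine or a longer ether chain would read here also remains open, as does whether a secondary carbamoyl smaller than (tert-butyl)carbamoyl would leave the limit at all.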